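The compounds below may be only part of what the source reports. "The series", "measured", "known", "first", "only" and "open" are said of these compounds alone.

The measured compounds:
compound 1, `Cc1nc(NCc2ccccc2)c2cnn(-c3ccccc3)c2n1`: > 100000 nM
compound 2, `CCNc1nc(C)nc2c1cnn2-c1ccccc1`: 38700 nM

In a functional assay on G-361 cells (Homo sapiens) for cytotoxicity, read by sulforhodamine B assay (on this read-out higher numbers stand for weaker inhibition of growth and lower numbers for stronger inhibition of growth), compound 1 reaches only a limit of the assay, > 100000 nM. In this assay compound 2 gives 38700 nM. The two differ in one place, methyl in place of phenyl on a saturated chain carbon bound to a nitrogen on an aromatic ring, and this brings an at least 2.5-fold lower number from compound 1 to compound 2 (0.41 log units; beyond the scatter). Compound 2 thus holds the only true number shown; the one further value is the limit of > 100000 nM in this assay, at which 1 of the 2 values shown sits.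

Compound 3, `CCNCc1nc(NCC)c2cnn(-c3ccccc3)c2n1`, differs from compound 2 in one place: ethylamino in place of hydrogen on a saturated chain carbon bound to an aromatic carbon. The single measured step concerns a different group at a different place, so no measured step bears on this change, and nothing shown says which way it will turn. The expected step is therefore a small one, a 1.0-fold higher number from compound 2 to compound 3 (0.01 log units; within the scatter), within the scatter. For compound 3 the estimate in this assay is 40000 nM, with a range from 10000 nM to 150000 nM.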

Compound 3, concentration for 50% growth inhibition: > 100000 nM
Compound 3 was reported as a limit; the forecaster's own chance of this, stated with the estimate: 30%; at least 2.5-fold (0.39 log units) between middle value and limit.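

In this assay, among these compounds, the earlier compounds changed only the group on the ring nitrogen side of the molecule, so the methyl group of compound 2 had not yet been tested as a place for change. Putting ethylamino in place of hydrogen on this saturated chain carbon bound to an aromatic carbon gives an at least 2.5-fold higher number from compound 2 to compound 3 (0.41 log units; beyond the scatter), so this position does respond to change, and this particular change goes towards weaker inhibition of growth. Compound 3 is reported only as a limit of the assay, so the true size of the loss cannot be read, and compound 2 remains the only compound with an exact number: the limit of > 100000 nM in this assay, at which 2 of the 3 values shown sit.

The compounds shown leave open whether the loss belongs to the nitrogen of the ethylamino group or simply to a longer chain at this carbon, a question that an ethoxy group or a plain propyl chain in the same place would address. They also leave open how a smaller amine such as aminomethyl, a ring amine such as morpholine, or a carboxylic acid would behave at this position.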